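Moving the Methyl Group on the Phenyl Ring

This account rests on a few compounds, and the source may have more. Where it says the series, first, only, none or still open, it means among the compounds named here.

Measured compounds:
compound 1 `O=[N+]([O-])c1ccc(N/C(=N\O)c2ccccc2Br)c2nonc12` – 80 nM
compound 2 `Cc1cccc(/C(=N/O)Nc2ccc([N+](=O)[O-])c3nonc23)c1` – 163 nM

Of the compounds shown here, two have been tested in an assay on isolated protein for inhibition of Indoleamine 2,3-dioxygenase 1 (Homo sapiens), read by spectrophotometry, with a stated time of 1 h; on this read-out lower numbers stand for stronger inhibition and higher numbers for weaker inhibition. Compound 1 gives 80 nM, and compound 2 gives 163 nM. Within the data shown here, compound 2 therefore has the higher of the two numbers, that is, the weaker inhibition, and the only step recorded so far, a 2.0-fold higher number from compound 1 to compound 2 (0.31 log units; beyond the scatter), separates it from compound 1.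

Compound 3 `Cc1ccc(/C(=N/O)Nc2ccc([N+](=O)[O-])c3nonc23)cc1` has not yet been measured. It differs from compound 2 in one place only: 4-methylphenyl in place of 3-methylphenyl on a carbon with a double bond to nitrogen. The same atoms are present, only the methyl group sits elsewhere on the phenyl ring.

Among the measured compounds shown here, no measured step shows what moving a methyl group on this ring does. For the measured compounds named here, the one known step, a 2.0-fold higher number from compound 1 to compound 2 (0.31 log units; beyond the scatter), swapped a bromine-bearing ring for a methyl-bearing ring, a different kind of change, and it was modest. With nothing closer to lean on, the expectation for compound 3 is a step of a 1.2-fold higher number from compound 2 to compound 3 (0.09 log units; within the scatter), which is not beyond the scatter. Compound 3 is thus estimated at 200 nM, within a range from 80 nM to 500 nM.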

Compound 3, half-maximal inhibitory concentration: 204 nM
Beside the measured number, compound 3's estimate is 1.0-fold (0.01 log units) below it; low and high end bracket the measured number.
By their numbers in this assay, from the lowest: compound 1; then compounds 2 and 3 (each within the scatter of the next).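

Moving the methyl group so that 4-methylphenyl replaces 3-methylphenyl gives, in this assay, a 1.3-fold higher number from compound 2 to compound 3 (0.10 log units; within the scatter), so on this carbon with a double bond to nitrogen the two methyl placements cannot be told apart by this read-out. The difference between the bromine-bearing and methyl-bearing rings holds for the second placement too: beside the earlier step, there is now a 2.6-fold higher number from compound 1 to compound 3 (0.41 log units; beyond the scatter), which leaves compound 1 the strongest inhibitor of the three. Nothing available explains why the numbers fall this way.

The compounds shown leave open whether the gap to compound 1 belongs to the bromine atom itself or to where it sits on the phenyl ring, since only one bromine-bearing compound appears here. From the compounds shown here alone, it also remains open how this position would respond to a group of a different kind on the phenyl ring, such as a methoxy group, an amine or a carboxylic acid.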